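The source may report more compounds than this note shows. Statements on the series, on what has been measured and on what is new or still open speak of the compounds shown alone.

Working notes on the series. In a functional assay on VCaP cells (Homo sapiens) for antiproliferative activity, read by propidium iodide staining, with a stated time of 96 h (on this read-out higher numbers stand for weaker inhibition and lower numbers for stronger inhibition), compound 1 `CC(O)(COc1ccc(C#N)cc1)C(=O)Nc1cccc(S(F)(F)(F)(F)F)c1` gives 26600 nM. Compound 2 `CC(O)(COc1ccc(C#N)cc1C(F)(F)F)C(=O)Nc1cccc(S(F)(F)(F)(F)F)c1` carries the change trifluoromethyl in place of hydrogen on an aromatic carbon and in this assay compound 2 gives 30600 nM, a step of a 1.2-fold higher number from compound 1 to compound 2 (0.06 log units; within the scatter). Compound 3 `CC(O)(CS(=O)(=O)c1cccc(C(F)(F)F)c1)C(=O)Nc1cccc(S(F)(F)(F)(F)F)c1` gives 35500 nM in this assay; the difference between the cores of compound 1 and compound 3 is not broken down here. Compound 4 `CC(O)(CS(=O)(=O)c1cc(C(F)(F)F)cc(C(F)(F)F)c1)C(=O)Nc1cccc(S(F)(F)(F)(F)F)c1` carries the same kind of change, (trifluoromethyl in place of hydrogen on an aromatic carbon). The surroundings of the place differ: in compound 2 the entering group is ortho to a large group and meta to a cyano group, in compound 4 it is meta to a large group and meta to a trifluoromethyl group. From compound 3 to compound 4 a step of a 1.1-fold higher number from compound 3 to compound 4 (0.05 log units; within the scatter) is expected, resting on the step of a 1.2-fold higher number from compound 1 to compound 2 (0.06 log units; within the scatter) staying within the scatter. For compound 4 the estimated value is 40000 nM, expected between 20000 nM and 80000 nM.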

Compound 4, half-maximal inhibitory concentration: 10400 nM
Estimate against measurement, compound 4: 3.8-fold (0.59 log units) above; the measured number lies below the stated range.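

In this assay, trifluoromethyl in place of hydrogen on an aromatic carbon gives a 3.4-fold lower number from compound 3 to compound 4 (0.53 log units; beyond the scatter). Set beside the earlier step, the same change does not carry over from one core to the other: the same change on two cores in this assay, a 1.2-fold higher number (0.06 log units; within the scatter) from compound 1 to compound 2 and a 3.4-fold lower number (0.53 log units; beyond the scatter) from compound 3 to compound 4, 3.9-fold (0.59 log units) apart, beyond the scatter of two such steps This rests on a single pair for each core, and the surroundings of the place also differ, so it gives neither a reason for the gap nor a rule for any other core.

The compounds shown leave open whether a chlorine atom, a methoxy group or an amine at the same place would give a step like that to compound 4. They also leave open how a nitrile at that place would compare on the core of compound 3.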